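Sulfonamide series: methoxy to trifluoromethyl on the distal ring

The source may report more compounds than this note shows. Statements on the series, on what has been measured and on what is new or still open speak of the compounds shown alone.

Compound 1 `COc1ccccc1-c1cccc(S(=O)(=O)N2CCC(N3CCC(C)CC3)CC2)c1` gives 21 nM in a functional assay on DLD-1 cells (Homo sapiens) for antiproliferative activity, read by CellTiter-Glo, with a stated time of 72 h; a lower number here means a stronger inhibitor, a higher number a weaker inhibitor. Among the three compounds measured it holds the second highest number: compound 2 `CC1CCN(C2CCN(S(=O)(=O)c3ccccc3-c3ccccc3)CC2)CC1` gives 0.96 nM, a lower number beyond the scatter, while compound 3 `Cc1cc(C)c(S(=O)(=O)NC2CCN(C3CCN(C)CC3)CC2)c(C)c1` gives 958 nM, a higher number beyond the scatter. No pair of these compounds differs in a single place, so no single-point step is available.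

Compound 4 `CC1CCN(C2CCN(S(=O)(=O)c3cccc(-c4ccccc4C(F)(F)F)c3)CC2)CC1` is not yet measured. It differs from compound 1 as follows: trifluoromethyl in place of methoxy on an aromatic carbon. Cut one bond further out, the difference reads 2-methoxyphenyl to 2-(trifluoromethyl)phenyl.

For compound 4 a small step is expected from compound 1, a 1.4-fold lower number from compound 1 to compound 4 (0.15 log units; within the scatter), in either direction or none beyond the scatter. Compound 4 is estimated at 15 nM, with a range from 5 nM to 60 nM.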

Compound 4, half-maximal inhibitory concentration: 10 nM
Compound 4: the middle estimate sits 1.5-fold (0.18 log units) above what was measured; the measured number falls inside the stated range.
By their numbers in this assay, from the lowest: compound 2; then compound 4; then compound 1; then compound 3.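

Read at a single point for the first time in the series, 2-methoxyphenyl to 2-(trifluoromethyl)phenyl in this assay gives a 2.1-fold lower number from compound 1 to compound 4 (0.32 log units; beyond the scatter). The methoxy oxygen is therefore not required at this position to hold a number of this order, and the larger trifluoromethyl is accepted there. Nothing available explains the step.

On these data alone, whether a nitrile, a chlorine or a hydroxyl at this place would continue the step remains open. So does whether a basic amine such as a dimethylaminomethyl group would be accepted there.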